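The source may report more compounds than this note shows. Statements on the series, on what has been measured and on what is new or still open speak of the compounds shown alone.

Compound 3 `CCN1CCN(CC(=O)Nc2ccc(-c3nc(-c4ccccc4)c(-c4ccccc4)n3C)cc2)CC1` stands at the bottom of the three numbers at hand. In a functional assay on MCF7 cells (Homo sapiens) for cytotoxicity, read by MTT assay, with a stated time of 24 h, tested at 0.64 ug/mL (on this read-out higher numbers stand for a stronger effect at the one concentration tested and lower numbers for a weaker effect), compound 3 gives 4.7%. Its nearest neighbour is compound 1 `Cn1c(-c2ccc(NC(=O)CSc3nc4ccccc4o3)cc2)nc(-c2ccccc2)c1-c1ccccc1`, which in this assay gives 18.7%; the step of a number 14 percentage points lower from compound 1 to compound 3 (beyond the scatter) separates the two. Compound 2 `Cn1cnnc1SCC(=O)Nc1ccc(-c2nc(-c3ccccc3)c(-c3ccccc3)n2C)cc1` lies furthest away: in this assay compound 2 gives 33.1%, and the step of a number 28.4 percentage points lower from compound 2 to compound 3 (beyond the scatter) is the largest among the measured steps. Between the two upper compounds the step of a number 14.4 percentage points higher from compound 1 to compound 2 (beyond the scatter) runs the other way.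

Compound 4 `Cn1c(-c2ccc(NC(=O)CN3CCN(Cc4ccc(Cl)cc4)CC3)cc2)nc(-c2ccccc2)c1-c1ccccc1` differs from compound 3 in one place: 4-chlorophenyl in place of methyl on a saturated chain carbon bound to an amine nitrogen in a ring. The change sits on the ethylpiperazine part that entered in the two measured steps down to compound 3, yet none of those steps alters this part itself; they only swap the whole side chain. Among the compounds with values here, no measured step therefore bears directly on the move from compound 3 to compound 4, and the sizes of the steps into compound 3 are the only guide to how much this end of the molecule can move the read-out.

On that basis a small rise is expected for compound 4, of about a number 9.3 percentage points higher from compound 3 to compound 4 (within the scatter), so that compound 4 is estimated in this assay at 14%, within 0% to 32%.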

Compound 4, a percentage reported as activity, at one concentration (the size of the read-out at that concentration, not a potency): 4.8%
The estimate for compound 4 lay 9.2 percentage points above the measured number; low and high end bracket the measured number.
By their numbers in this assay, from the lowest: compounds 3 and 4 (each within the scatter of the next); then compound 1; then compound 2.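

In this assay, the exchange of methyl for 4-chlorophenyl on a saturated chain carbon bound to an amine nitrogen in a ring gives a number 0.1 percentage points higher from compound 3 to compound 4 (within the scatter), so adding a six-membered aromatic ring of carbon only, with 7 heavy atoms entering where 1 leaves, produces no difference that can be told from the scatter. Within the data shown here, the earlier steps into compound 3 replaced the whole group on the saturated chain carbon bound to a carbonyl carbon, whereas this pair is the first to hold the piperazine in place and vary only its outer end, and ethyl and 4-chlorobenzyl at that end cannot be told apart here. Nothing on hand accounts for this result.

As far as these compounds go, whether the same holds for other groups at this place, such as an aminoethyl group, a carboxylic acid or a longer alkyl chain, remains open. From the compounds shown here alone, both numbers also come from a single concentration, so it remains open whether compound 3 and compound 4 would also match at other concentrations.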